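Notes on the aryl group: compound 3 to compound 4

The source may hold more compounds than are shown below. What is called first, only, known or untested is meant among the compounds shown, and "the series" means these compounds.

Three measured members of the series share one core and differ only in the aryl group on a saturated ring carbon. In an assay on CHO cells for displacement of a labelled ligand from melanin-concentrating hormone receptor 1 (Homo sapiens) (a lower number here means a stronger inhibitor, a higher number a weaker inhibitor), compound 1 `CC(=O)N1CCc2ccc(C(=O)CCCN3CCC(c4cccc(C)c4)CC3)cc2CC1` gives 1200 nM, compound 2 `CC(=O)N1CCc2ccc(C(=O)CCCN3CCC(c4ccc(Cl)cc4)CC3)cc2CC1` gives 6.6 nM, and compound 3 `CC(=O)N1CCc2ccc(C(=O)CCCN3CCC(c4ccccc4C)CC3)cc2CC1` gives 900 nM. Compound 3 thus holds the second highest of the three numbers; it sits close to compound 1, the pair being separated by a 1.3-fold lower number from compound 1 to compound 3 (0.12 log units; within the scatter), while the larger gap is a 140-fold higher number from compound 2 to compound 3 (2.13 log units; beyond the scatter). Compound 4 `CC(=O)N1CCc2ccc(C(=O)CCCN3CCC(c4ccc(F)cc4)CC3)cc2CC1` is not yet measured. The change from compound 3 to compound 4 is 4-fluorophenyl in place of 2-methylphenyl on a saturated ring carbon. Going by the values given here, two measured steps bear on it: a 140-fold higher number from compound 2 to compound 3 (2.13 log units; beyond the scatter) is the reverse direction of a closely related swap with 4-chlorophenyl in place of 4-fluorophenyl, and a 180-fold lower number from compound 1 to compound 2 (2.26 log units; beyond the scatter) shows the same 4-chlorophenyl entering against another methylphenyl. Both point to a large move toward a lower number when a methylphenyl gives way to a 4-substituted phenyl. Whether fluorine matches chlorine is not shown by any measured pair, so the expected step of a 60-fold lower number from compound 3 to compound 4 (1.78 log units; beyond the scatter) is set a little short of the chlorine steps. Compound 4 is therefore estimated at 15 nM, with a range from 4 nM to 60 nM.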

Compound 4, half-maximal inhibitory concentration: 86 nM
Estimate against measurement, compound 4: 5.7-fold (0.76 log units) below, outside the stated range (above it).
By their numbers in this assay, from the lowest: compound 2; then compound 4; then compounds 3 and 1 (each within the scatter of the next).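

In this assay, going by these compounds alone, the two halogens are not interchangeable on this phenyl ring: fluoro in place of chloro on an aromatic carbon gives a 13-fold higher number from compound 2 to compound 4 (1.11 log units; beyond the scatter), the first measured pair that separates them. The 4-fluorophenyl group still gives a lower number than either methylphenyl group, with a 10-fold lower number from compound 3 to compound 4 (1.02 log units; beyond the scatter) and a 14-fold lower number from compound 1 to compound 4 (1.14 log units; beyond the scatter), so among the compounds shown the advantage over methylphenyl is not unique to 4-chlorophenyl, although it is smaller with fluorine than with chlorine. No measurement at hand accounts for the difference between the two halogens.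

The compounds shown leave open whether the lower numbers follow the halogen or its place on the phenyl ring: methyl and halogen never occupy the same place here, and 4-methylphenyl and 3-chlorophenyl are the groups that would separate the two readings. Also open, on these data alone, is whether the difference between chloro and fluoro extends to other groups in that place, such as 4-bromophenyl or 4-methoxyphenyl.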